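Bromo in Place of Carboxy on a Shared Core

The source may report more compounds than this note shows. Statements on the series, on what has been measured and on what is new or still open speak of the compounds shown alone.

Of the compounds shown here, three sharing one core have been measured in an assay for inhibition of Tryptophan 2,3-dioxygenase (Homo sapiens), with stated times of 10 min and 60 min, tested at 10 uM; a higher number here means a stronger effect of the compound at the concentration tested, a lower number a weaker effect. Compound 2 `O=C(O)c1cccc(CNc2cc(C(F)(F)F)cc3[nH]ncc23)c1` gives 81%. Compound 1 `Oc1ccc(CNc2cc(C(F)(F)F)cc3[nH]ncc23)cc1` gives 75%, a gap that lies within the scatter, while compound 3 `O=[N+]([O-])c1ccc(CNc2cc(C(F)(F)F)cc3[nH]ncc23)cc1` gives 47%, a gap beyond it. For the measured compounds named here, the only measured step, a number 28 percentage points lower from compound 1 to compound 3 (beyond the scatter), is the sole guide available. Compound 4 `FC(F)(F)c1cc(NCc2cccc(Br)c2)c2cn[nH]c2c1` differs from compound 2 by bromo in place of carboxy on an aromatic carbon. Going by the values given here, no measured step exchanges carboxy for bromo, so the expectation leans on compound 3, where a number 28 percentage points lower from compound 1 to compound 3 (beyond the scatter) accompanied the loss of the hydroxy. A downward step of modest size is therefore expected, a number 26 percentage points lower from compound 2 to compound 4 (beyond the scatter). Compound 4 is estimated at 55%, with a range from 30% to 80%.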

Compound 4, a percentage reported as inhibition, at one concentration (the size of the read-out at that concentration, not a potency): 67%
Compound 4: the middle estimate sits 12 percentage points below what was measured; the measured number falls inside the stated range.
By their numbers in this assay, from the lowest: compound 3; then compounds 4, 1 and 2 (each within the scatter of the next, the first and the last beyond it).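

Putting bromo in place of carboxy on this aromatic carbon lowers the read-out but leaves much of it in place: a number 14 percentage points lower from compound 2 to compound 4 (beyond the scatter). The entering bromo has no hydrogen-bond donor or acceptor, yet a number 8 percentage points lower from compound 1 to compound 4 (within the scatter), so among these compounds a carboxy is not required for a read-out close to that of compound 1. No available evidence explains this result. The compounds shown leave open how a chloro, a methoxy or an amine on the same aromatic carbon would read in this assay.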